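The source may hold more compounds than are shown below. What is called first, only, known or untested is meant among the compounds shown, and "the series" means these compounds.

Three measured analogues share one core. Compound 1 `CSc1cc(NC2CCCC2)cc2c(-c3ccnc(NC4CCCC4)n3)c(-c3ccc(F)cc3)nn12` bears a methylsulfanyl group and a fluoro on the aromatic ring. In an ADME assay on Vero cells (Chlorocebus sabaeus) for cytotoxicity (a higher number here means that more compound is tolerated, a lower number that less compound is tolerated), compound 1 gives only a limit, > 40000 nM. Compound 2 `CC(C)Sc1cc(NC2CCCC2)cc2c(-c3ccnc(NC4CCCC4)n3)c(-c3ccc(F)cc3)nn12` has isopropyl in place of methyl on the sulfur; in this assay compound 2 also returns a limit, > 40000 nM. Compound 3 `COc1ccc(-c2nn3c(SC)cc(NC4CCCC4)cc3c2-c2ccnc(NC3CCCC3)n2)cc1` has methoxy in place of fluoro; in this assay compound 3 likewise returns a limit, > 40000 nM. Compound 3 thus stands at the limit, as do all other values (the limit of > 40000 nM in this assay, at which 3 of the 3 values shown sit). Both steps, a step that the two limits leave unreadable from compound 1 to compound 2 and a step that the two limits leave unreadable from compound 1 to compound 3, are unreadable. Compound 4 `COc1ccc(-c2nn3c(SC(C)C)cc(NC4CCCC4)cc3c2-c2ccnc(NC3CCCC3)n2)cc1` differs from compound 3 by isopropyl in place of methyl on a sulfur. The same change from compound 1 to compound 2 left both values at the limit, so no step beyond the scatter is expected in this assay. Compound 4 is expected at 50000 nM, range 30000 nM to 120000 nM. The expected step is a step that the limit leaves unreadable from compound 3 to compound 4.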

Compound 4, half-maximal cytotoxic concentration: > 40000 nM
Compound 4 gave a limit, no number (the forecaster's own chance of this, stated with the estimate: 90%); the middle value does not contradict the limit.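

Neither the step from compound 3 to compound 4 nor the step from compound 2 to compound 4 can be read in this assay, since every value is a limit: the limit of > 40000 nM in this assay, at which 4 of the 4 values shown sit. The compounds shown leave open whether either isopropyl in place of methyl on a sulfur or methoxy in place of fluoro on an aromatic carbon changes the tolerated concentration at all.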